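This account rests on a few compounds, and the source may have more. Where it says the series, first, only, none or still open, it means among the compounds named here.

Compound 2 `CNC(=O)N1CCCc2ccc(NC(=O)c3ccc(-c4ccccn4)cc3)cc21` shares its core with compound 1 `CNC(=O)N1CCCc2ccc(NC(=O)c3ccc(-c4ccncc4)cc3)cc21`, the two differing only in the position of the nitrogen in the pyridyl ring. In a functional assay on MV4-11 cells (Homo sapiens) for antiproliferative activity, with a stated time of 6 days, tested at 1.56 uM (on this read-out lower numbers stand for a weaker effect and higher numbers for a stronger effect at the one concentration tested), compound 1 gives 37.6%, and in this assay compound 2 gives 32%; the shift a number 5.6 percentage points lower from compound 1 to compound 2 (within the scatter) lies within the usual scatter, so the two numbers cannot be told apart. Compound 3 `CNC(=O)N1CCCc2ccc(NC(=O)c3ccc(-c4cccnc4)cc3)cc21` continues the same exchange at the same place: pyridin-3-yl in place of pyridin-2-yl on an aromatic carbon. For the measured compounds named here, the only measured step that bears on this change is the one from pyridin-4-yl to pyridin-2-yl, and it was small. Moving the nitrogen once more is therefore expected to give no step beyond the scatter, so the step of a number 3 percentage points higher from compound 2 to compound 3 (within the scatter) from compound 2 to compound 3 is estimated to be close to nothing. For compound 3 a value of 35% is expected, with a likely range from 22% to 48%.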

Compound 3, a percentage reported as inhibition, at one concentration (the size of the read-out at that concentration, not a potency): 62.5%
For compound 3 the middle estimate is 27.5 percentage points below the measured one; measured number outside the range, above it.
By their numbers in this assay, from the lowest: compounds 2 and 1 (each within the scatter of the next); then compound 3.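

In this assay, the place of the ring nitrogen now proves to matter at this position, which the earlier pair could not show: pyridin-3-yl stands apart, with a number 30.5 percentage points higher from compound 2 to compound 3 (beyond the scatter) and a number 24.9 percentage points higher from compound 1 to compound 3 (beyond the scatter). The groups that change places have the same atoms and the same counts of donors and acceptors, so these steps come from how the ring is joined alone, on an aromatic carbon para to a large group. Nothing measured here accounts for the difference.

The compounds shown leave open whether a plain phenyl ring or a pyrimidin-5-yl ring would match pyridin-3-yl at this place. They also leave open how far the difference would carry over to a potency, since each number is the size of the effect at one concentration.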